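Swapping halogens on the amide ring: cytotoxicity outlook

The compounds below may be only part of what the source reports. "The series", "measured", "known", "first", "only" and "open" are said of these compounds alone.

Compound 1 `O=C(Nc1ncc(C(Oc2ccc3cc(Br)ccc3c2)c2ccc(Cl)cc2)s1)c1ccc(F)cc1F` was recorded in an ADME assay on HepG2 2.2.15 cells (Homo sapiens) for cytotoxicity (on this read-out higher numbers stand for lower toxicity in this test and lower numbers for higher toxicity in this test), as "not toxic" (no number reported), without a number. Compound 2 `O=C(Nc1ncc(C(Oc2ccc3cc(Br)ccc3c2)c2ccc(Cl)cc2)s1)c1ccc(F)cc1Br` reaches only a limit of this assay, > 50000 nM. In this read-out compound 2 therefore sits at the limit of > 50000 nM in this assay, at which 1 of the 2 values shown sits, so no exact figure is known for it. Compound 3 `O=C(Nc1ncc(C(Oc2ccc3cc(Br)ccc3c2)c2ccc(Cl)cc2)s1)c1cc(F)c(F)cc1F` differs from compound 2 by 2,4,5-trifluorophenyl in place of 2-bromo-4-fluorophenyl on a carbonyl carbon. For the measured compounds named here, no measured pair shows what this change does, so no shift beyond the usual scatter is expected, and compound 3 is estimated to stay at the limit as well, with a step that the limit leaves unreadable from compound 2 to compound 3. Compound 3 is expected to give 60000 nM, within 30000 nM to 120000 nM.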

Compound 3, half-maximal cytotoxic concentration: "not toxic" (no number reported)
No number was reported for compound 3; no gap can be computed for the estimate.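

Compound 3 came back as "not toxic" without a number, and compound 2 holds only a limit, so no step can be read between compound 2 and compound 3. On these data alone, how far cytotoxicity in this assay actually differs across these amide ring halogen patterns remains open.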